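The source may hold more compounds than are shown below. What is called first, only, known or untested is meant among the compounds shown, and "the series" means these compounds.

Series notes. In a functional assay on LOX IMVI cells (Homo sapiens) for inhibition, read by sulforhodamine B assay, with a stated time of 48 h (a higher number here means a weaker inhibitor of growth, a lower number a stronger inhibitor of growth), compound 1 `O=C(Cc1csc2nc(-c3ccc(Br)cc3)cn12)N/N=C/c1ccccc1` gives 12300 nM, compound 2 `O=C(Cc1csc2nc(-c3ccc(Br)cc3)cn12)N/N=C/c1ccccc1O` gives 3470 nM and compound 3 `O=C(Cc1csc2nc(-c3ccc(Br)cc3)cn12)N/N=C/c1ccc(O)cc1` gives 11200 nM. Compound 3 thus stands second highest of the three numbers: the step of a 1.1-fold lower number from compound 1 to compound 3 (0.04 log units; within the scatter) lies within the scatter, whereas a 3.5-fold lower number from compound 1 to compound 2 (0.55 log units; beyond the scatter) and a 3.2-fold higher number from compound 2 to compound 3 (0.51 log units; beyond the scatter) are modest. Compound 4 `O=C(Cc1csc2nc(-c3ccc(Br)cc3)cn12)N/N=C/c1ccc(Cl)cc1Cl` carries 2,4-dichlorophenyl in place of 4-hydroxyphenyl on a carbon with a double bond to nitrogen. For the measured compounds named here, no measured step involves a chloro group; the only guide is that taking the hydroxy away from compound 3 would return to the level of compound 1, as a 1.1-fold lower number from compound 1 to compound 3 (0.04 log units; within the scatter) shows, so in this assay a step no larger than the scatter is expected, a 1.2-fold lower number from compound 3 to compound 4 (0.09 log units; within the scatter), with wide uncertainty from the two chlorines. Compound 4 is therefore estimated at 9000 nM, in the range 2500 nM to 32000 nM.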

Compound 4, concentration for 50% growth inhibition: 21400 nM
Estimate against measurement, compound 4: 2.4-fold (0.38 log units) below, within the range that was stated.
By their numbers in this assay, from the lowest: compound 2; then compounds 3, 1 and 4 (each within the scatter of the next).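

In this assay, 2,4-dichlorophenyl on this carbon reads level with both 4-hydroxyphenyl and phenyl, since a 1.9-fold higher number from compound 3 to compound 4 (0.28 log units; within the scatter) and a 1.7-fold higher number from compound 1 to compound 4 (0.24 log units; within the scatter) both lie within the scatter. Only 2-hydroxyphenyl stands apart, with a 6.2-fold higher number from compound 2 to compound 4 (0.79 log units; beyond the scatter) beyond the scatter, so compound 2 is now separated from all three other compounds. No measurement at hand accounts for this.

Open, going by these compounds, is whether 2-methoxyphenyl or 2-aminophenyl on this carbon would match 2-hydroxyphenyl. Also open, on these data alone, is whether a single chlorine, as in 2-chlorophenyl, would read differently from 2,4-dichlorophenyl.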